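Cyclopropyl to cyclopentyl on the amide: working notes

The source may report more compounds than this note shows. Statements on the series, on what has been measured and on what is new or still open speak of the compounds shown alone.

- compound 1 `CC(C)=CCC/C(C)=C/CC/C(C)=C/CSC[C@H](NC(=O)CCCCCN1CCN(C)CC1)C(=O)NC1CC1`: 6300 nM
- compound 2 `CC(C)=CCC/C(C)=C/CC/C(C)=C/CSc1ccccc1C(N)=O`: > 20000 nM (a limit)
- compound 3 `CC(C)=CCC/C(C)=C/CC/C(C)=C/CSC[C@H](NC(=O)CCCCCN1CCN(C)CC1)C(=O)NC1CCCC1`: not yet measured

Going by the values given here, in a functional assay on BXPC-3 cells (Homo sapiens) for cytotoxicity, read by fluorescence, with a stated time of 48 h (on this read-out higher numbers stand for an effect only at larger amounts of compound and lower numbers for an effect already at smaller amounts), compound 1 gives 6300 nM, the only actual number so far. Compound 2 reaches only a limit of the assay. Compound 3 differs from compound 1 by cyclopentyl in place of cyclopropyl on an amide-type nitrogen, with cyclopentyl in place of cyclopropyl on an amide-type nitrogen. Among the compounds with values here, no measured pair shows this change, so any expectation is weakly supported. The expected step in this assay is small, within the usual scatter and if anything toward lower numbers, at an estimated 1.4-fold lower number from compound 1 to compound 3 (0.15 log units; within the scatter). For compound 3 the estimated value is 4500 nM, with an expected range of 1800 nM to 13000 nM.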

Compound 3, half-maximal effective concentration: > 20000 nM
Compound 3 gave a limit, no number; the forecaster's own chance of this, stated with the estimate: 10%; middle value at least 4.4-fold (0.64 log units) from the limit.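

Cyclopentyl in place of cyclopropyl on an amide-type nitrogen is the only one-place change shown, and in this assay it gives an at least 3.1-fold higher number from compound 1 to compound 3 (0.50 log units; beyond the scatter). This position is therefore not indifferent to the ring it carries: the effect seen with compound 1 is not kept with the five-membered ring. Compound 3 sits at a limit of the assay, not at a number, so its step has no upper end: the limit of > 20000 nM in this assay, at which 2 of the 3 values shown sit.

From the compounds shown here alone, whether cyclobutyl or an open-chain isopropyl on the same nitrogen keeps the value of compound 1 stays open. So does the effect of a plain primary amide there.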